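Series notes: step from compound 3 to compound 4

This account rests on a few compounds, and the source may have more. Where it says the series, first, only, none or still open, it means among the compounds named here.

Compound 1 `CCNc1cc(Nc2cccc(Cl)c2)ncn1`: in an assay for inhibition of Receptor tyrosine-protein kinase erbB-3 variant L858R (Homo sapiens), read by mobility shift assay, with a stated time of 10 min (a lower number here means a stronger inhibitor, a higher number a weaker inhibitor), compound 1 gives > 10000 nM, a limit of the assay (the limit of > 10000 nM in this assay, at which 1 of the 3 values shown sits).
Compound 2 `O=C(Nc1cc(Nc2ccc(Cl)cc2)ncn1)c1ccc(F)cc1`: in this assay compound 2 gives 1610 nM.
Compound 3 `O=C(O)CCC(=O)Nc1cc(Nc2ccc(Cl)cc2)ncn1`: in this assay compound 3 gives 825 nM.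

Compound 3 holds the lowest of the two numbers; its gap to compound 2, a 2.0-fold lower number from compound 2 to compound 3 (0.29 log units; within the scatter), lies within the scatter. Compound 4 `Clc1ccc(Nc2cc(Nc3cccc(Cl)n3)ncn2)cc1` differs from compound 3 by 6-chloropyridin-2-yl in place of (2-carboxyethyl)carbonyl on a nitrogen on an aromatic ring. Going by the values given here, no measured step exchanges an acyl group for an aromatic ring on this nitrogen; the only numbered step, a 2.0-fold lower number from compound 2 to compound 3 (0.29 log units; within the scatter), changes the group on the carbonyl carbon and stays within the scatter, while compound 1 with ethyl on that nitrogen reaches only the limit. For compound 4 the expected value in this assay is 1000 nM, with a range of 200 nM to 5000 nM. The step of a 1.2-fold higher number from compound 3 to compound 4 (0.08 log units; within the scatter) that this estimate means is expected to stay within the scatter, though the range is wide.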

Compound 4, half-maximal inhibitory concentration: 236 nM
Compound 4: middle estimate off by 4.2-fold (0.63 log units), on the high side; low and high end bracket the measured number.
By their numbers in this assay, from the lowest: compound 4; then compounds 3 and 2 (each within the scatter of the next). At a limit, above all of these: compound 1.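

In this assay an aromatic ring can replace an acyl group on this nitrogen without loss, and a 3.5-fold lower number from compound 3 to compound 4 (0.54 log units; beyond the scatter) comes with 6-chloropyridin-2-yl in place of (2-carboxyethyl)carbonyl. Going by these compounds alone, the earlier step of a 2.0-fold lower number from compound 2 to compound 3 (0.29 log units; within the scatter) changed only the group on the carbonyl carbon, so this is the first step to go beyond the scatter. No measurement shown gives a cause for this step. Open, from the compounds shown here alone, is which part of 6-chloropyridin-2-yl carries the step: a plain phenyl, an unsubstituted pyridin-2-yl or a methyl in place of the chlorine would separate the ring nitrogen from the chlorine.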